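Replacing a sulfur-bearing group with an ester at the chain carbon

The source may report more compounds than this note shows. Statements on the series, on what has been measured and on what is new or still open speak of the compounds shown alone.

Measured compounds:
- compound 1, `COCc1c(C)nc2c(OCc3ccccc3)cccn12`: 99%
- compound 2, `CCOCc1c(C)nc2c(OCc3ccccc3)cccn12`: 84%
- compound 3, `Cc1nc2c(OCc3ccccc3)cccn2c1C[S+](C)[O-]`: 0%

All three share one core and differ only in the group carried on a saturated chain carbon bound to an aromatic carbon. In a functional assay on the whole organism with Rattus norvegicus as the target, with a stated time of 4 h, at a dose of 40 mg/kg by the intraperitoneal route (on this read-out lower numbers stand for less inhibition and higher numbers for more inhibition at the one dose given (going by the name of the read-out)), compound 3 stands lowest of the three, far beneath compound 2 and compound 1 alike. The two steps that reach compound 3 both bear directly on the next change: a number 99 percentage points lower from compound 1 to compound 3 (beyond the scatter) and a number 84 percentage points lower from compound 2 to compound 3 (beyond the scatter). In each case a group holding one carbon, one oxygen and one sulfur took the place of a short oxygen-containing chain, and inhibition collapsed. Compound 4, `CCCCC(=O)OCc1c(C)nc2c(OCc3ccccc3)cccn12`, reverses that kind of swap: a group of 7 heavy atoms (5 carbon, 2 oxygen; no ring) in place of a group of 3 heavy atoms (1 carbon, 1 oxygen, 1 sulfur; no ring), on a saturated chain carbon bound to an aromatic carbon. The entering group again has no sulfur and again holds oxygen, as the groups in compound 1 and compound 2 do. A large rise in this assay is therefore expected, back toward the level of those two compounds. Compound 4 is expected to give 78%, within a range of 45% to 100%. This estimate corresponds to a number 78 percentage points higher from compound 3 to compound 4 (beyond the scatter).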

Compound 4, a percentage reported as inhibition, in the whole organism at one dose (the size of the read-out at that dose, not a potency): 45%
Beside the measured number, compound 4's estimate is 33 percentage points above it; the range from low to high includes it.
By their numbers in this assay, from the lowest: compound 3; then compound 4; then compound 2; then compound 1.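

In this assay, replacing the sulfur-bearing group with (butylcarbonyl)oxy at this saturated chain carbon bound to an aromatic carbon recovers much of the inhibition (a number 45 percentage points higher from compound 3 to compound 4 (beyond the scatter)). The recovery is only partial, and the new group falls well short of the two short oxygen-containing chains (a number 39 percentage points lower from compound 2 to compound 4 (beyond the scatter); a number 54 percentage points lower from compound 1 to compound 4 (beyond the scatter)), so among these compounds, lacking sulfur does not by itself bring back the highest numbers. Nothing available explains why butylcarbonyl on this oxygen gives less inhibition than ethyl or methyl.

Butylcarbonyl differs from ethyl and methyl both by its carbonyl and by its longer chain, so these compounds cannot show which of the two goes with the lower number. As far as these compounds go, an acetyl group on the same oxygen, a free hydroxyl or an amine at this carbon remains open.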